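This account rests on a few compounds, and the source may have more. Where it says the series, first, only, none or still open, it means among the compounds named here.

Three compounds share one core, in which a sulfonylurea joins a chlorophenyl ring to a five-membered aromatic ring with one sulfur, and they differ only in the group on that ring. Compound 1 `O=C(Nc1ccc(Cl)cc1)NS(=O)(=O)c1ccc(Cl)s1` carries a chloro there; in a functional assay on the whole organism (6C3HED cells, Mus musculus) for inhibition, at a dose of 150 mg/kg by the oral route (a higher number here means more inhibition at the dose given (going by the name of the read-out), a lower number less inhibition), compound 1 gives 58%. Compound 2 `CSc1ccc(S(=O)(=O)NC(=O)Nc2ccc(Cl)cc2)s1` carries a methylsulfanyl, and compound 2 gives 29%. Compound 3 `CCOc1ccc(S(=O)(=O)NC(=O)Nc2ccc(Cl)cc2)s1` carries an ethoxy, and compound 3 gives 69%, the highest of the three, with compound 1 nearest and compound 2 furthest.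

Compound 4 `CC(C)(C)c1ccc(S(=O)(=O)NC(=O)Nc2ccc(Cl)cc2)s1` is the next step: tert-butyl in place of ethoxy on an aromatic carbon. The steps measured so far change the same position: a number 11 percentage points higher from compound 1 to compound 3 (beyond the scatter), a number 40 percentage points higher from compound 2 to compound 3 (beyond the scatter) and a number 29 percentage points lower from compound 1 to compound 2 (beyond the scatter). None of them puts a tert-butyl there, so there is no direct guide; they show only that this position matters, and that ethoxy has done better than either a chloro or a methylsulfanyl. A tert-butyl has no hydrogen-bond acceptor and is the largest group yet tried, so a drop from compound 3 is expected, of about a number 24 percentage points lower from compound 3 to compound 4 (beyond the scatter). Compound 4 is therefore estimated at 45%, somewhere between 15% and 75%.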

Compound 4, a percentage reported as inhibition, in the whole organism at one dose (the size of the read-out at that dose, not a potency): 7%
Compound 4: the middle estimate sits 38 percentage points above what was measured; measured number below the stated range.
By their numbers in this assay, from the lowest: compound 4; then compound 2; then compound 1; then compound 3.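

In this assay, tert-butyl gives the lowest number of the four, and the fall is clear against every other group tried: (a number 62 percentage points lower from compound 3 to compound 4 (beyond the scatter)), (a number 51 percentage points lower from compound 1 to compound 4 (beyond the scatter)) and (a number 22 percentage points lower from compound 2 to compound 4 (beyond the scatter)). The earlier compounds shown here showed that this position separates ethoxy, chloro and methylsulfanyl, while this result shows that a group here can remove most of the inhibition seen with ethoxy at this dose. Ethoxy has a hydrogen-bond acceptor and tert-butyl has none, but that is only one of several differences between the two groups, and nothing shown gives a measured reason for the fall.

The compounds shown leave open how a methoxy, an amine or a longer ether chain such as butoxy would fare at this position. Going by these compounds, whether ethoxy is close to the best group here therefore remains unknown.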